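The source may report more compounds than this note shows. Statements on the series, on what has been measured and on what is new or still open speak of the compounds shown alone.

Measured compounds:
compound 1 `COc1cc2c(Oc3ccc(NC(=O)c4cc(-c5ccc(F)cc5)ccn4)cc3F)ccnc2cc1OCCCN1CCCCC1` — in a functional assay on NCI-H460 cells (Homo sapiens) for cytotoxicity, read by MTT assay, with a stated time of 72 h (on this read-out higher numbers stand for weaker inhibition and lower numbers for stronger inhibition), compound 1 gives 250 nM
compound 2 `COc1cc2c(Oc3ccc(NC(=O)c4cc(-c5ccc(F)cc5)ccn4)cc3F)ccnc2cc1OCCCN1CCN(C)CC1` — in this assay compound 2 gives 430 nM

Going by the values given here, only two compounds have been measured so far. Among the compounds with values here, compound 2 is the one with the larger number of the two, but the step of a 1.7-fold higher number from compound 1 to compound 2 (0.24 log units; within the scatter) tells that the two values cannot be told apart on this read-out. Both share the same core and differ only in the ring attached to the saturated chain.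

Compound 3 `COc1ccc(-c2ccnc(C(=O)Nc3ccc(Oc4ccnc5cc(OCCCN6CCN(C)CC6)c(OC)cc45)c(F)c3)c2)c(OC)c1` alters a different part of the molecule. The change is 2,4-dimethoxyphenyl in place of 4-fluorophenyl on an aromatic carbon. Within the data shown here, the single measured step, from compound 1 to compound 2, concerns the saturated chain and not this aromatic group, so no measured step bears on the change from compound 2 to compound 3. With nothing in the data to point one way or the other, the step is expected to be a 1.2-fold higher number from compound 2 to compound 3 (0.07 log units; within the scatter), that is, nothing beyond the scatter, though with wide uncertainty in either direction. Compound 3 is therefore estimated at 500 nM in this assay, within a range from 120 nM to 2500 nM.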

Compound 3, half-maximal inhibitory concentration: 430 nM
Compound 3: the middle estimate sits 1.2-fold (0.07 log units) above what was measured; the measured number falls inside the stated range.
By their numbers in this assay, from the lowest: compounds 1, 2 and 3 (each within the scatter of the next).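

On the aromatic carbon opposite the ring nitrogen, 2,4-dimethoxyphenyl in place of 4-fluorophenyl gives no change at the digits printed from compound 2 to compound 3 (within the scatter) in this assay. The earlier pair differed only in the ring on the saturated chain, whereas this pair shows that the aryl position can change from a group of 7 heavy atoms with 0 hydrogen-bond acceptors to one of 10 heavy atoms with 2 hydrogen-bond acceptors without a shift beyond the scatter, at least with the 4-methylpiperazin-1-yl chain in place. The data offer no explanation for why these two groups read alike in this cell assay.

As far as these compounds go, one swap replaces the fluorine and adds two methoxy groups at once, so the separate contributions of 2-methoxyphenyl and 4-methoxyphenyl remain open, as does the reading of an unsubstituted phenyl. From the compounds shown here alone, it also remains open whether a group of a different kind on this ring, such as a carboxylic acid or an aminomethyl group, would read the same, and whether 2,4-dimethoxyphenyl would match 4-fluorophenyl when paired with the piperidin-1-yl chain of compound 1.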